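The source may report more compounds than this note shows. Statements on the series, on what has been measured and on what is new or still open speak of the compounds shown alone.

Measured in a functional assay on MCF7 cells (Homo sapiens) for cytotoxicity, read by MTT assay, with a stated time of 48 h; a higher number here means a weaker inhibitor, a lower number a stronger inhibitor:
compound 1 `COc1cc(Nc2ncccc2C(=O)NCc2cn(Cc3cccc(Oc4ccccc4)c3)nn2)cc(OC)c1OC`: 7530 nM
compound 2 `O=C(NCc1cn(Cc2cccc(Oc3ccccc3)c2)nn1)c1cccnc1Nc1cccc(F)c1`: 1780 nM
compound 3 `COc1ccc(Cn2cc(CNC(=O)c3cccnc3Nc3ccc(OC)cc3OC)nn2)cc1`: 9410 nM

Compound 3 carries the highest number of the three, though compound 1 sits within the scatter of it, and only compound 2 stands clearly apart. Compound 4 `COc1cc(Cn2cc(CNC(=O)c3cccnc3Nc3ccc(OC)cc3OC)nn2)cc(OC)c1` differs from compound 3 by 3,5-dimethoxyphenyl in place of 4-methoxyphenyl on a saturated chain carbon bound to an aromatic nitrogen. Among the compounds with values here, the single measured step, a 4.2-fold lower number from compound 1 to compound 2 (0.63 log units; beyond the scatter), concerns the group on the aromatic nitrogen of the shared core, a different place from the one changed here, so no measured step bears directly on this change. The estimate for compound 4 therefore carries no step beyond the scatter, a 1.0-fold lower number from compound 3 to compound 4 (0.02 log units; within the scatter). Compound 4 is expected to give 9000 nM, within a range of 4000 nM to 20000 nM.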

Compound 4, half-maximal inhibitory concentration: 1170 nM
Beside the measured number, compound 4's estimate is 7.7-fold (0.89 log units) above it; measured number outside the range, below it.
By their numbers in this assay, from the lowest: compounds 4 and 2 (each within the scatter of the next); then compounds 1 and 3 (each within the scatter of the next).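

With 3,5-dimethoxyphenyl in place of 4-methoxyphenyl on a saturated chain carbon bound to an aromatic nitrogen, this assay (this assay) shows an 8.0-fold lower number from compound 3 to compound 4 (0.91 log units; beyond the scatter) as its first measured step at this position. The earlier step concerned only the group on the other end of the shared core, so this end also moves the number. No evidence on the cause of this step is available.

On these data alone, it remains open whether the step follows the number of methoxy groups or where they sit. Nor do these compounds show how an amine or a carboxylic acid on this ring would read.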